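Swapping 2-methylphenyl for 4-chlorophenyl on the shared core

This account rests on a few compounds, and the source may have more. Where it says the series, first, only, none or still open, it means among the compounds named here.

- compound 1 `O=C1Nc2ccc(F)cc2C1=Cc1ccc(-c2cn(-c3ccccc3)nn2)cc1` gives 8120 nM
- compound 2 `Cc1ccccc1-n1cc(-c2ccc(C=C3C(=O)Nc4ccc(F)cc43)cc2)nn1` gives 5870 nM

Both values come from a functional assay on HT-29 cells (Homo sapiens) for inhibition, read by CCK-8 assay, with a stated time of 24 h (on this read-out lower numbers stand for stronger inhibition and higher numbers for weaker inhibition), and compound 2 stands within the usual scatter of compound 1, so the two cannot be told apart. Compound 3 `O=C1Nc2ccc(F)cc2C1=Cc1ccc(-c2cn(-c3ccc(Cl)cc3)nn2)cc1` has not been measured. It carries 4-chlorophenyl in place of 2-methylphenyl on an aromatic nitrogen (in counts: 4-chlorophenyl in place of 2-methylphenyl on an aromatic nitrogen). Among the compounds with values here, one measured step bears on this change: a 1.4-fold lower number from compound 1 to compound 2 (0.14 log units; within the scatter) came with methyl in place of hydrogen on an aromatic carbon and stayed within the scatter. Within the data shown here, no measured compound carries chlorine, so this evidence is thin. The expected change is small, with no shift beyond the scatter foreseen in this assay (estimated: a 1.1-fold lower number from compound 2 to compound 3 (0.03 log units; within the scatter)). Compound 3 is estimated at 5500 nM (expected range 2200 nM to 13000 nM).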

Compound 3, half-maximal inhibitory concentration: 11200 nM
For compound 3 the middle estimate is 2.0-fold (0.31 log units) below the measured one; low and high end bracket the measured number.
By their numbers in this assay, from the lowest: compounds 2, 1 and 3 (each within the scatter of the next).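

Exchanging 2-methylphenyl for 4-chlorophenyl on the aromatic nitrogen gives a 1.9-fold higher number from compound 2 to compound 3 (0.28 log units; within the scatter) in this assay and stays small. Adding chloro to the phenyl group gives a 1.4-fold higher number from compound 1 to compound 3 (0.14 log units; within the scatter) and also stays small, so chlorine, new to this set, brings no step beyond the scatter, and the three groups tried at this position cannot be told apart in this read-out. Nothing measured here explains these numbers.

Going by these compounds, all three compounds keep a carbon-only aromatic ring on this nitrogen, so it remains open whether a ring carrying an amine or a carboxylic acid, or a longer alkyl chain in place of the ring, would give a step beyond the scatter. On these data alone, whether bromo would behave like chloro is also open.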